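Dropping one chloro from a dichlorophenyl ring

The source may hold more compounds than are shown below. What is called first, only, known or untested is meant among the compounds shown, and "the series" means these compounds.

Measured so far:
- compound 1, `COc1ccc(Cl)cc1-n1ncc(-c2nnc(-c3cccc(F)c3)o2)c1C`, 4.28
- compound 2, `COc1ccc(Cl)cc1-n1ncc(-c2nnc(-c3ccc(Cl)c(Cl)c3)o2)c1C`, 5.57

Both compounds share the same core and differ only in the outer ring. Going by the values given here, in a physicochemical assay for lipophilicity, using the shake flask method, measured as octanol-water partition (a higher number here means a more lipophilic compound, a lower number a more polar compound), compound 2 stands highest of the two numbers; its only neighbour is compound 1, and the single measured step, a number 1.29 log units higher from compound 1 to compound 2 (beyond the scatter), lies well beyond the scatter.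

Compound 3, `COc1ccc(Cl)cc1-n1ncc(-c2nnc(-c3ccc(Cl)cc3)o2)c1C`, has not been measured yet. The change from compound 2 is hydrogen in place of chloro on an aromatic carbon. Among the compounds with values here, the one measured step bears on it only loosely: from compound 1 to compound 2 one chloro was added and a fluoro became a chloro, and the number rose strongly. Taking one chloro away again is expected to send this assay down, by a step estimated at a number 0.65 log units lower from compound 2 to compound 3 (beyond the scatter). For compound 3 the expected value is therefore 4.92, in a range from 4.5 to 5.3.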

Compound 3, partition coefficient: 4.51
Compound 3: middle estimate off by 0.41 log units, on the high side; the range from low to high includes it.
By their numbers in this assay, from the lowest: compounds 1 and 3 (each within the scatter of the next); then compound 2.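

In this assay, one chloro on the outer ring accounts for a large difference: hydrogen in its place, ortho to a chloro group, gives a number 1.06 log units lower from compound 2 to compound 3 (beyond the scatter) and so removes most of the separation seen earlier. Swapping the outer rings of the other two compounds gives a number 0.23 log units higher from compound 1 to compound 3 (within the scatter) and does not separate them, so among these three compounds only the 3,4-dichlorophenyl compound stands apart. Nothing available explains why this single change has so large an effect.

From the compounds shown here alone, it remains open whether a group other than chloro or hydrogen at this carbon, such as an amine, a carboxylic acid or a longer chain, would keep the number high or bring it down. Going by these compounds, whether hydrogen in place of chloro would give a similar step on a different core also remains open.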